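Methoxy for chloro on a second, related core

The source may hold more compounds than are shown below. What is called first, only, known or untested is meant among the compounds shown, and "the series" means these compounds.

Measured so far in a physicochemical assay for lipophilicity, at pH 7.4; on this read-out lower numbers stand for lower lipophilicity and higher numbers for higher lipophilicity:
compound 1 `COc1ccc(C2Cc3nccn3C2)cc1` gives 2
compound 2 `Clc1ccccc1C1CCc2nc[nH]c2C1` gives 3.1
compound 3 `Clc1ccc(C2Cc3nccn3C2)cc1` gives 2.6

Compound 1 and compound 3 share a core and differ in one place, (methoxy in place of chloro on an aromatic carbon), and this change made a step of a number 0.60 log units lower from compound 3 to compound 1 (beyond the scatter). Compound 4 `COc1ccccc1C1CCc2nc[nH]c2C1` is not yet measured; it relates to compound 2 in the same kind of way, (methoxy in place of chloro on an aromatic carbon), though here the place is ortho to a group of 9 heavy atoms, whereas in compound 1 it is para to a group of 8 heavy atoms. The difference between the two cores is not broken down here. Compound 2 stands highest of the three measured values. Because the earlier step was a number 0.60 log units lower from compound 3 to compound 1 (beyond the scatter), a step of about a number 0.60 log units lower from compound 2 to compound 4 (beyond the scatter) is expected from compound 2 to compound 4. Compound 4 is therefore estimated at 2.5 in this assay.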

Compound 4, distribution coefficient: 2.8
Compound 4: middle estimate off by 0.30 log units, on the low side; measured number inside the range.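

In this assay, methoxy in place of chloro on the core of compound 2 gives a step of a number 0.30 log units lower from compound 2 to compound 4 (within the scatter), while the same change on the core of compound 1 gave a number 0.60 log units lower from compound 3 to compound 1 (beyond the scatter). The change therefore moved the read-out beyond the scatter on one core but not on the other, although a single pair on each core sets no rule for the series, and the two pairs differ in both core and place of change. Nothing shown here explains the contrast between the two steps. As far as these compounds go, it remains open whether an amine or a carboxylic acid in place of chloro would give matching steps on these two cores.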